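Swapping the Aryl Group on the Lipoic Acid-Coumarin Hybrid

This account rests on a few compounds, and the source may have more. Where it says the series, first, only, none or still open, it means among the compounds named here.

Measured so far:
compound 1 `O=C(CCCCC1CCSS1)NCc1cn(CCCOc2ccc3ccc(=O)oc3c2)nn1` — 39.2%
compound 2 `O=C(CCCCC1CCSS1)NCc1cn(CCCOc2ccc3cc(C(=O)O)c(=O)oc3c2)nn1` — 57%
compound 3 `COc1ccc(-c2cc3ccc(OCCCCn4cc(CNC(=O)CCCCC5CCSS5)nn4)cc3oc2=O)cc1` — 44.9%

Three compounds have been run in a functional assay on PC-12 cells (Rattus norvegicus) for cytotoxicity, read by MTT assay, with stated times of 3 h and 2 h, tested at 5 uM; a lower number here means a weaker effect, a higher number a stronger effect of the compound at the concentration tested. Compound 1 gives 39.2% in this assay, and compound 2 gives 57%. Among the compounds with values here, the one step between these two, a number 17.8 percentage points higher from compound 1 to compound 2 (beyond the scatter), comes from a carboxy in place of hydrogen on an aromatic carbon. Compound 3 sits second of the three numbers with 44.9%: its gap to compound 1 lies within the scatter, while compound 2 stands beyond the scatter above it.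

Compound 4 `O=C(CCCCC1CCSS1)NCc1cn(CCCCOc2ccc3cc(-c4ccc(Cl)c(Cl)c4)c(=O)oc3c2)nn1` is not yet measured. It differs from compound 3 in one place: 3,4-dichlorophenyl in place of 4-methoxyphenyl on an aromatic carbon. Within the data shown here, no measured pair shows this kind of exchange of one aryl group for another; the only measured step, from compound 1 to compound 2, concerns a carboxy group and does not bear on it. With nothing to go on but the unchanged remainder of the structure, the expected step in this assay, a number 2.1 percentage points higher from compound 3 to compound 4 (within the scatter), is none beyond the scatter. Compound 4 is therefore estimated at 47%, with a range from 30% to 64%.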

Compound 4, a percentage reported as activity, at one concentration (the size of the read-out at that concentration, not a potency): 53.2%
Beside the measured number, compound 4's estimate is 6.2 percentage points below it, within the range that was stated.
By their numbers in this assay, from the lowest: compounds 1, 3, 4 and 2 (each within the scatter of the next, the first and the last beyond it).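

In this assay, within the data shown here, the exchange of 4-methoxyphenyl for 3,4-dichlorophenyl gives a number 8.3 percentage points higher from compound 3 to compound 4 (within the scatter), the first reading of one aryl group replacing another on this aromatic carbon of the shared core. The step shows that this position accepts the two chlorine atoms in place of the methoxy group, with its hydrogen-bond acceptor, without a difference that can be told from the usual scatter in this read-out, although this rests on a single pair of compounds. No measured evidence is available to explain the size of this step.

The compounds shown leave open whether an unsubstituted phenyl, an aminophenyl or a pyridine ring at this position would give a step beyond the scatter. Compound 3 and compound 4 also differ from compound 1 and compound 2 in more than one place, so the contribution of an aryl group at this position, as against a hydrogen or a carboxylic acid there, cannot be read from these compounds.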